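From compound 1 to compound 4: an added isopropyl

A few compounds are considered here, and "the series" means these few. Any claim that something is new, unique, unknown or untested is made for them only; others in the source may bear on it.

Values so far in an ADME assay on WI-38 cells (Homo sapiens) for cytotoxicity, read by MTT assay, with a stated time of 72 h (on this read-out higher numbers stand for weaker inhibition and lower numbers for stronger inhibition), for the series
compound 1 `O=C(CCc1cccc2c1B(O)OC2)Nc1ccccc1` gives 30000 nM as a true number
compound 2 `C#Cc1ccc(NC(=O)CCc2cccc3c2B(O)OC3)cc1` gives > 100000 nM as a limit
compound 3 `O=C(CCc1cccc2c1B(O)OC2)Nc1ccc([N+](=O)[O-])cc1` gives > 100000 nM as a limit

Among the compounds with values here, compound 1 gives 30000 nM as the only true number. The other two values stand at the limit of > 100000 nM in this assay, at which 2 of the 3 values shown sit, and are limits only.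

From the compounds shown here alone, the compound still open is compound 4 `CC(C)c1cccc(NC(=O)CCc2cccc3c2B(O)OC3)c1` and it departs from compound 1 by a single change isopropyl in place of hydrogen on an aromatic carbon with isopropyl in place of hydrogen on an aromatic carbon.

Within the data shown here, two measured steps bear on this change. Ethynyl in place of hydrogen gives an at least 3.3-fold higher number from compound 1 to compound 2 (0.52 log units; beyond the scatter) and nitro in place of hydrogen gives an at least 3.3-fold higher number from compound 1 to compound 3 (0.52 log units; beyond the scatter) and both point towards weaker inhibition. Going by these compounds, each of them ends at a limit, so their true size remains open. Among the measured compounds shown here, neither entering group is isopropyl, and no measured compound carries it. A step in the same direction is therefore expected in this assay but a small one that may stay within the scatter. The expected change is a 1.5-fold higher number from compound 1 to compound 4 (0.18 log units; within the scatter) as an estimate. For compound 4 the estimated value is 45000 nM with an expected range from 15000 nM to 100000 nM in this estimate.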

Compound 4, half-maximal inhibitory concentration: 22000 nM
Estimate against measurement, compound 4: 2.0-fold (0.31 log units) above, within the range that was stated.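

In this assay, isopropyl in place of hydrogen on an aromatic carbon, meta to a large group, gives a 1.4-fold lower number from compound 1 to compound 4 (0.13 log units; within the scatter). A new group on this ring therefore does not by itself move the series towards weaker inhibition: compound 4 goes against the direction seen with ethynyl in compound 2 and nitro in compound 3. Compound 4 also gives a true number, so this change can be read at its full size, unlike the steps to compound 2 and compound 3, which end at limits: the limit of > 100000 nM in this assay, at which 2 of the 4 values shown sit.

Ethynyl and nitro sit at a different place on the ring from isopropyl, so the compounds shown do not separate the effect of the group from that of its place. From the compounds shown here alone, it remains open whether isopropyl would match compound 4 at the place held by ethynyl in compound 2, and whether an amine or a carboxylic acid, meta to a large group, would stay within the scatter of compound 1.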